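Bromo to Fluoro on Two Related Thiazolidine Cores

The source may hold more compounds than are shown below. What is called first, only, known or untested is meant among the compounds shown, and "the series" means these compounds.

Measured compounds:
compound 1, `COc1ccc(/C=C2/CN(C)/C(=N/c3ccc(Br)cc3)S2)cc1`, 8900 nM
compound 2, `COc1ccc(/C=C2/CN(C)/C(=N/c3ccc(F)cc3)S2)cc1`, 10000 nM
compound 3, `COc1ccc(/C=C2\S/C(=N\c3ccc(Br)cc3)N(C)C2=O)cc1`, 17000 nM

The three measured compounds were tested in a functional assay on HCT-116 cells (Homo sapiens) for antiproliferative activity, read by MTT assay, with a stated time of 72 h; a higher number here means a weaker inhibitor, a lower number a stronger inhibitor. Compound 1 gives 8900 nM and compound 2 gives 10000 nM. The change from compound 1 to compound 2 is fluoro in place of bromo on an aromatic carbon, and it produced a 1.1-fold higher number from compound 1 to compound 2 (0.05 log units; within the scatter). Compound 3 sits on a different core and gives 17000 nM in this assay; the difference between its core and the core of compound 1 is not broken down here. Its value lies close to those of compound 1 and compound 2.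

Compound 4, `COc1ccc(/C=C2\S/C(=N\c3ccc(F)cc3)N(C)C2=O)cc1`, is not yet measured. It differs from compound 3 by fluoro in place of bromo on an aromatic carbon. Going by the values given here, this is the same change as that from compound 1 to compound 2, made at the same place, so the earlier step is the only guide. Because the step of a 1.1-fold higher number from compound 1 to compound 2 (0.05 log units; within the scatter) fell within the scatter, the step from compound 3 to compound 4 is also expected to be small, estimated as a 1.1-fold higher number from compound 3 to compound 4 (0.05 log units; within the scatter). On this basis compound 4 is expected to give about 19000 nM in this assay, with a plausible range from 9000 nM to 40000 nM. The estimate rests on a single pair and carries the uncertainty of that pair.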

Compound 4, half-maximal inhibitory concentration: 13300 nM
Estimate against measurement, compound 4: 1.4-fold (0.15 log units) above, and the stated range covers the measured number.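

In this assay, fluoro in place of bromo gave a 1.3-fold lower number from compound 3 to compound 4 (0.11 log units; within the scatter), so on the core of compound 3 this change left the number within the scatter, as it had on the core of compound 1. Set side by side, the two steps do not differ, and in this series the swap of the two halogens carried from one core to the other with no readable shift in antiproliferative activity: the same change on two cores in this assay, a 1.1-fold higher number (0.05 log units; within the scatter) from compound 1 to compound 2 and a 1.3-fold lower number (0.11 log units; within the scatter) from compound 3 to compound 4, 1.4-fold (0.16 log units) apart, within the scatter of two such steps. Going by these compounds alone, this does not show that the change would stay as small on any further core, as the comparison rests on only two pairs, and the opposite directions of the two small steps cannot be read as a real reversal between the cores.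

The compounds shown leave open whether any group at this place on the aromatic ring can move the number beyond the scatter, as only the 4-bromophenyl and 4-fluorophenyl forms appear here, and a nitrile, a carboxylic acid or an amine might behave differently. They also leave open whether the two cores would still respond alike with a longer chain in place of the methyl group.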